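Lengthening a methoxy group on a weak aortic inhibitor

The compounds below may be only part of what the source reports. "The series", "measured", "known", "first", "only" and "open" are said of these compounds alone.

Measured compounds:
compound 1, `COc1nc(-c2cc3ccccc3o2)cc(-c2ccccc2)c1C#N`, 232000 nM
compound 2, `COc1cc(-c2cc(-c3cc4ccccc4o3)nc(OC)c2C#N)cc(OC)c1OC`, 310000 nM

Both compounds were tested in a functional assay on aorta (strain Wistar) for inhibition, with Thoracic aorta (Rattus norvegicus) as the target; on this read-out higher numbers stand for weaker inhibition and lower numbers for stronger inhibition. In this assay compound 1 gives 232000 nM, and compound 2 gives 310000 nM. The two numbers lie within the scatter of each other, so compound 2 cannot be told apart from compound 1 on this read-out; both are weak inhibitors.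

Compound 3, `CCOc1nc(-c2cc3ccccc3o2)cc(-c2cc(OC)c(OC)c(OC)c2)c1C#N`, keeps the core of compound 2 and differs in one place: methyl in place of hydrogen on a saturated chain carbon bound to an oxygen on an aromatic ring, that is, methyl to ethyl, methoxy to ethoxy. Going by the values given here, no pair of measured compounds shows the effect of such a change, so the only guide is the small size of the difference. The step from compound 2 to compound 3 is expected to be none beyond the scatter, a 1.0-fold lower number from compound 2 to compound 3 (0.01 log units; within the scatter). Compound 3 is therefore estimated at 300000 nM, with a range from 120000 nM to 750000 nM.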

Compound 3, half-maximal inhibitory concentration: 365000 nM
For compound 3 the middle estimate is 1.2-fold (0.09 log units) below the measured one, and the stated range covers the measured number.
By their numbers in this assay, from the lowest: compounds 1, 2 and 3 (each within the scatter of the next).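

In this assay, going by these compounds alone, methyl in place of hydrogen on a saturated chain carbon bound to an oxygen on an aromatic ring gives a 1.2-fold higher number from compound 2 to compound 3 (0.07 log units; within the scatter), the first one-place change that can be read. Methoxy to ethoxy at this position therefore leaves compound 3 indistinguishable from compound 2 on this read-out, although this single pair cannot establish a general rule. Nothing available explains this result or bears on it.

From the compounds shown here alone, whether a longer chain such as propoxy or butoxy, or an amine at this position, would move the number beyond the scatter remains open. Going by these compounds, it is also open whether methoxy to ethoxy would have an equally small effect on a compound with much stronger inhibition.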